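From Hydroxy to Methoxy: Compound 2 to Compound 4

This account rests on a few compounds, and the source may have more. Where it says the series, first, only, none or still open, it means among the compounds named here.

Of the compounds shown here, three have been tested in an assay on isolated protein for inhibition of glutathione S-transferase A2 (Homo sapiens), read by spectrophotometry, with a stated time of 3 min, tested at 100 uM; a lower number here means less inhibition, a higher number more inhibition at the concentration tested (going by the name of the read-out). Compound 1 `CC(=O)OCC1=CC(=O)[C@H](O)[C@@H](O)[C@@H]1O` gives 18%. Compound 2 `CO[C@]1(C)O[C@H]2[C@H](O)C=C(COC(C)=O)C(=O)[C@@H]2O[C@@]1(C)OC` gives 15%, and compound 3 `CO[C@]1(C)O[C@H]2[C@H](O)C(CO)=CC(=O)[C@@H]2O[C@@]1(C)OC` gives 19%. Compound 2 sits within the usual scatter of both compound 1 and compound 3, and the three numbers cannot be told apart. Compound 4 `CO[C@@H]1C=C(COC(C)=O)C(=O)[C@@H]2O[C@@](C)(OC)[C@](C)(OC)O[C@@H]12` has not yet been measured. It differs from compound 2 in one place: methyl in place of hydrogen on an oxygen on a saturated carbon. Going by the values given here, no pair of measured compounds differs in a single place, and there is no measured step for a change of this kind. With all three measured numbers close together, the step of a number 1 percentage points higher from compound 2 to compound 4 (within the scatter) is expected to stay within the scatter. Compound 4 is therefore estimated at 16%, in a range from 6% to 28%.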

Compound 4, a percentage reported as inhibition, at one concentration (the size of the read-out at that concentration, not a potency): 16%
The estimate for compound 4 equals the measured number at the digits printed; measured number inside the range.
By their numbers in this assay, from the lowest: compounds 2, 4, 1 and 3 (each within the scatter of the next).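

In this assay, going by these compounds alone, the change from hydroxy to methoxy gives the first step in one place, a number 1 percentage points higher from compound 2 to compound 4 (within the scatter). For this pair, a methyl can take the place of the hydrogen on this oxygen on a saturated carbon without a change that can be read at the concentration tested. Nothing shown here accounts for this result. From the compounds shown here alone, it remains open whether a longer chain on this oxygen, or an amine or a carboxylic acid in place of the hydroxy, would move the number beyond the scatter. A single step also cannot show whether the same change would behave alike elsewhere on the core.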